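Working notes: 4-ethylphenyl to 3,4-dimethylphenyl exchange

The compounds below may be only part of what the source reports. "The series", "measured", "known", "first", "only" and "open" are said of these compounds alone.

Measured so far in a functional assay on MGC-803 cells (Homo sapiens) for inhibition, read by sulforhodamine B assay; a higher number here means a weaker inhibitor, a lower number a stronger inhibitor:
- compound 1 `O=C1C(Nc2ccc(Br)cc2)=CC(=O)c2c1nc1n2[C@H]2OC[C@@H](O)[C@H]2OC1` gives 2020 nM
- compound 2 `CCc1ccc(NC2=CC(=O)c3c(nc4n3[C@H]3OC[C@@H](O)[C@H]3OC4)C2=O)cc1` gives 1110 nM

Only these two compounds have been measured, and compound 2 stands within the scatter of compound 1, so it holds no clear place of its own on these numbers. Compound 3 `Cc1ccc(NC2=CC(=O)c3c(nc4n3[C@H]3OC[C@@H](O)[C@H]3OC4)C2=O)cc1C` is still unmeasured. It keeps the shared core of compound 2 and carries 3,4-dimethylphenyl in place of 4-ethylphenyl on an amine nitrogen.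

Among the measured compounds shown here, one measured step bears on this change, and only indirectly. That step, ethyl in place of bromo on an aromatic carbon, is a 1.8-fold lower number from compound 1 to compound 2 (0.26 log units; within the scatter) and lies within the scatter. No measurement tests the exchange in compound 3 directly. With that single step as the guide, no step beyond the scatter is expected in this assay and neither direction is favoured. The expected step is small (a 1.1-fold higher number from compound 2 to compound 3 (0.03 log units; within the scatter)). Compound 3 is estimated at 1200 nM (expected range 500 nM to 2800 nM).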

Compound 3, half-maximal inhibitory concentration: 1050 nM
Estimate against measurement, compound 3: 1.1-fold (0.06 log units) above; low and high end bracket the measured number.
By their numbers in this assay, from the lowest: compounds 3, 2 and 1 (each within the scatter of the next).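

In this assay, the exchange on the amine nitrogen keeps the same atoms but joins them differently, and it gives a 1.1-fold lower number from compound 2 to compound 3 (0.02 log units; within the scatter). Among the compounds shown here, this is the first compound with two methyl groups on the phenyl ring rather than a single group, and it also gives a 1.9-fold lower number from compound 1 to compound 3 (0.28 log units; within the scatter), so 4-bromophenyl, 4-ethylphenyl and 3,4-dimethylphenyl cannot be told apart at this position in this assay. No information is available that would explain this result or link it to any property of the groups.

Still open, as far as these compounds go, is whether any group at this position moves the number beyond the scatter, for example a phenyl ring carrying a carboxylic acid or an amine, or one carrying a longer chain in place of ethyl. Also open, from the compounds shown here alone, is whether the three compounds stay this close when the aromatic ring on the amine nitrogen is replaced by an open alkyl chain, since all three carry a six-membered aromatic ring of carbon only.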